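Extending the amide of compound 1 with a carboxymethyl group

The compounds below may be only part of what the source reports. "The series", "measured", "known", "first", "only" and "open" are said of these compounds alone.

The measured compounds:
compound 1, `CNC(=O)/C=C/c1ccncc1-c1ccc2ccccc2c1`, 12.4 nM in an assay on a protein complex for inhibition of CDK8/Cyclin C (Homo sapiens), with a stated time of 1 h; a lower number here means a stronger inhibitor, a higher number a weaker inhibitor
compound 2, `CCOC(=O)/C=C/c1ccncc1-c1ccc2c(cnn2C)c1`, 102 nM in this assay
compound 3, `NNC(=O)CCc1ccncc1-c1ccc2ccccc2c1`, 7.7 nM in this assay

Compound 1 stands second highest of the three numbers. Its nearest neighbour is compound 3, reached by a 1.6-fold lower number from compound 1 to compound 3 (0.21 log units; within the scatter), a change that stays within the scatter. Within the data shown here, compound 2 is furthest from it; that compound carries an ethyl ester and a different core, so no single step connects it to compound 1, and the two values show only that compound 2 is the weaker of the two.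

The unmeasured compound 4, `O=C(O)CCNC(=O)/C=C/c1ccncc1-c1ccc2ccccc2c1`, differs from compound 1 by carboxymethyl in place of hydrogen on a saturated chain carbon bound to an amide-type nitrogen. Among the measured compounds shown here, the one measured step that bears on this is the amide change from compound 1 to compound 3, which altered the group on the amide nitrogen and the chain between amide and core without moving the number beyond the scatter. For the measured compounds named here, no measured pair tests a carboxylic acid on this chain, so the expectation rests on that step alone: a step of no more than scatter size in this assay, with no direction claimed.

Compound 4 is therefore expected to give 15 nM, within 5 nM to 45 nM, which amounts to an estimated 1.2-fold higher number from compound 1 to compound 4 (0.08 log units; within the scatter).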

Compound 4, half-maximal inhibitory concentration: 870 nM
Beside the measured number, compound 4's estimate is 58-fold (1.76 log units) below it; the whole stated range lies below it.
By their numbers in this assay, from the lowest: compounds 3 and 1 (each within the scatter of the next); then compound 2; then compound 4.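

In this assay, the step from the methylcarbamoyl group to the (2-carboxyethyl)carbamoyl group is large (a 70-fold higher number from compound 1 to compound 4 (1.85 log units; beyond the scatter)), so the number at this amide nitrogen can move far beyond the scatter with a change on the saturated chain alone. The earlier step on this part of the molecule did not show that: it stayed within the scatter (a 1.6-fold lower number from compound 1 to compound 3 (0.21 log units; within the scatter)), although it altered both the amide nitrogen's group and the chain that links the amide to the core, so the amide end had looked open to change on that evidence. Nothing available gives a reason for the size of the new step.

The compounds shown leave open whether this step belongs to the carboxylic acid itself or to the longer chain that carries it. That question would turn on a methyl ester, a primary amide or an amine at the end of the same chain, and on a carboxylic acid held on a shorter or longer chain from the same amide nitrogen.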